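The compounds below may be only part of what the source reports. "The series", "measured", "known", "first", "only" and "open" are said of these compounds alone.

Of the compounds shown here, three that share one core have so far been tested in an in vitro functional assay on CHO/Galpha16 cells for antagonist activity at C-C chemokine receptor type 8 (Homo sapiens), read by FLIPR; a higher number here means a weaker inhibitor, a lower number a stronger inhibitor. Compound 1 `CCCC(=O)N1CCC(NS(=O)(=O)c2ccc(NC(=O)c3cccc(C)c3)c3ccccc23)CC1` gives 5.1 nM. Compound 2 `CCCC(=O)N1CCC(NS(=O)(=O)c2ccc(NC(=O)c3ccc(C(C)(C)C)cc3)c3ccccc23)CC1` gives 6.9 nM. Compound 3 `CCCC(=O)N1CCC(NS(=O)(=O)c2ccc(NC(=O)c3cc(C)oc3C(F)(F)F)c3ccccc23)CC1` gives 46.9 nM, the highest number of the three; the steps reaching it are a 9.2-fold higher number from compound 1 to compound 3 (0.96 log units; beyond the scatter) and a 6.8-fold higher number from compound 2 to compound 3 (0.83 log units; beyond the scatter), while a 1.4-fold higher number from compound 1 to compound 2 (0.13 log units; within the scatter) shows the two phenyl variants sitting within the scatter of each other.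

Compound 4 `CCCC(=O)N1CCC(NS(=O)(=O)c2ccc(NC(=O)C3CCCC3)c3ccccc23)CC1` has not yet been measured. It differs from compound 3 in one place: cyclopentyl in place of 5-methyl-2-(trifluoromethyl)furan-3-yl on a carbonyl carbon. Both measured steps that lead to compound 3 exchange one aromatic ring for another aromatic ring, and both raised the number. Within the data shown here, no measured step shows what a non-aromatic ring does on this carbonyl carbon, so the expectation for compound 4 rests on weaker ground than the earlier comparisons. Because a 9.2-fold higher number from compound 1 to compound 3 (0.96 log units; beyond the scatter) and a 6.8-fold higher number from compound 2 to compound 3 (0.83 log units; beyond the scatter) mark compound 3 as the weakest of the measured set, there is room for compound 4 to fall back toward the phenyl pair, but also no evidence that it must. The expected step is therefore a 2.3-fold lower number from compound 3 to compound 4 (0.37 log units; beyond the scatter), a modest drop in the number with wide uncertainty. The estimate for compound 4 is 20 nM, within a range from 5 nM to 100 nM.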

Compound 4, half-maximal inhibitory concentration: 365 nM
For compound 4 the middle estimate is 18-fold (1.26 log units) below the measured one, outside the stated range (above it).
By their numbers in this assay, from the lowest: compounds 1 and 2 (each within the scatter of the next); then compound 3; then compound 4.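

In this assay, this carbonyl carbon is the first place in the series where a non-aromatic ring can be judged, and cyclopentyl does clearly worse than any aromatic ring shown: the change from the furan gives a further rise in the number (a 7.8-fold higher number from compound 3 to compound 4 (0.89 log units; beyond the scatter)), and the gaps to the two phenyl variants are large (a 53-fold higher number from compound 2 to compound 4 (1.72 log units; beyond the scatter); a 72-fold higher number from compound 1 to compound 4 (1.85 log units; beyond the scatter)). Compound 3 therefore no longer marks the weak end of the set, and among these four compounds the three with an aromatic ring here all have lower numbers than compound 4, with none going against that pattern. Nothing available explains why the number rises with this change.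

Compound 4 differs from the others in more than the loss of aromaticity, since its ring is also smaller than the furan group with its methyl and trifluoromethyl groups and carries no added groups of its own, so these four compounds cannot separate those differences. An unsubstituted phenyl, a methylcyclopentyl or a cyclohexyl on this carbonyl carbon would help to tell them apart, and a straight pentyl chain would show what happens with no ring at all.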